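The Same Aryl Swap Repeated on a Second Pair

This account rests on a few compounds, and the source may have more. Where it says the series, first, only, none or still open, it means among the compounds named here.

Measured in a functional assay on MCF7 cells (Homo sapiens) for cytotoxicity, read by MTT assay, with a stated time of 24 h; a lower number here means a stronger inhibitor, a higher number a weaker inhibitor:
compound 1 `CCCCc1nc(Cl)c(C=O)n1CCCOc1cc2c(Nc3ccc(OC)cc3)ncnc2cc1OC` gives 14000 nM
compound 2 `CCCCc1nc(Cl)c(C=O)n1CCCOc1cc2c(Nc3cccc(I)c3)ncnc2cc1OC` gives 3000 nM
compound 3 `CCCCc1nc(Cl)c(CO)n1CCCOc1cc2c(Nc3ccc(OC)cc3)ncnc2cc1OC` gives 20000 nM

Compounds 1 and 2 differ by 3-iodophenyl in place of 4-methoxyphenyl on a nitrogen on an aromatic ring, and this change gave a 4.7-fold lower number from compound 1 to compound 2 (0.67 log units; beyond the scatter). Compounds 1 and 3 differ in the core, namely (hydroxymethyl in place of formyl on an aromatic carbon), with a 1.4-fold higher number from compound 1 to compound 3 (0.15 log units; within the scatter). For the measured compounds named here, no pair among the three shares the two values within the scatter, so compound 3 simply stands with the highest number and compound 2 with the lowest.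

Compound 4 `CCCCc1nc(Cl)c(CO)n1CCCOc1cc2c(Nc3cccc(I)c3)ncnc2cc1OC` has not been measured. It differs from compound 3 by 3-iodophenyl in place of 4-methoxyphenyl on a nitrogen on an aromatic ring, the same change that was made from compound 1 to compound 2. Because a 4.7-fold lower number from compound 1 to compound 2 (0.67 log units; beyond the scatter) was the size of that step on the formyl-bearing core, a step of similar size is expected on the hydroxymethyl-bearing core of compound 3, that is a 4.7-fold lower number from compound 3 to compound 4 (0.67 log units; beyond the scatter). Compound 4 is therefore estimated at 4300 nM in this assay, expected to fall between 1800 nM and 10000 nM. This rests on a single earlier instance of the change, so the range is kept broad.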

Compound 4, half-maximal inhibitory concentration: 9950 nM
Compound 4: middle estimate off by 2.3-fold (0.36 log units), on the low side; measured number inside the range.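

In this assay, 3-iodophenyl in place of 4-methoxyphenyl on the hydroxymethyl-bearing core gave a 2.0-fold lower number from compound 3 to compound 4 (0.30 log units; within the scatter), and this step cannot be told apart from the one on the formyl-bearing core: the same change on two cores in this assay, a 4.7-fold lower number (0.67 log units; beyond the scatter) from compound 1 to compound 2 and a 2.0-fold lower number (0.30 log units; within the scatter) from compound 3 to compound 4, 2.3-fold (0.37 log units) apart, within the scatter of two such steps. Read the other way round, hydroxymethyl in place of formyl gave a 3.3-fold higher number from compound 2 to compound 4 (0.52 log units; beyond the scatter), and this step too agrees with its earlier counterpart: the same change on two cores in this assay, a 1.4-fold higher number (0.15 log units; within the scatter) from compound 1 to compound 3 and a 3.3-fold higher number (0.52 log units; beyond the scatter) from compound 2 to compound 4, 2.3-fold (0.37 log units) apart, within the scatter of two such steps. For the compounds shown here, the four compounds thus show no measurable dependence of either change on the group it is paired with, but they do not show that the steps are equal in size, since the step on the hydroxymethyl-bearing core alone cannot be separated from the scatter and only two pairs exist for each change.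

The compounds shown leave open whether the aryl swap would carry over to a core bearing a carboxylic acid or an amine in place of the formyl or hydroxymethyl group. They also leave open whether a chlorophenyl group on that nitrogen would behave like 3-iodophenyl.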